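The compounds below may be only part of what the source reports. "The series", "measured", "known", "first", "only" and "open" are said of these compounds alone.

Measured so far:
Compound 1, `CCOC(=O)OCOC(=O)C1=C(S[C@@H]2CN[C@H](C(=O)Nc3cccc(C(=O)O)c3)C2)[C@H](C)[C@@H]2[C@@H]([C@@H](C)O)C(=O)N12`: 10%
Compound 2, `COC(=O)OCOC(=O)C1=C(S[C@@H]2CN[C@H](C(=O)Nc3cccc(C(=O)O)c3)C2)[C@H](C)[C@@H]2[C@@H]([C@@H](C)O)C(=O)N12`: 33%
Compound 3, `C[C@@H](O)[C@H]1C(=O)N2C(C(=O)O)=C(S[C@@H]3CN[C@H](C(=O)Nc4cccc(C(=O)OCOC(=O)C(C)(C)C)c4)C3)[C@H](C)[C@H]12`: 53%

In an ADME assay on a cell-free system (plasma, Homo sapiens) for metabolic stability, read by LC-MS, with a stated time of 60 min, at 37 degrees C, tested at 50 uM (a higher number here means that more of the compound is left, a lower number that less of the compound is left), compound 1 gives 10%, compound 2 gives 33% and compound 3 gives 53%. The step of a number 23 percentage points higher from compound 1 to compound 2 (beyond the scatter) rests on one change, (hydrogen in place of methyl on a saturated chain carbon bound to an oxygen next to a carbonyl group). Compound 3 and compound 1 share no counted difference; the difference between the two cores is not broken down here. Compound 4, `CC(C)C(=O)OCOC(=O)c1cccc(NC(=O)[C@@H]2C[C@H](SC3=C(C(=O)O)N4C(=O)[C@H]([C@@H](C)O)[C@H]4[C@H]3C)CN2)c1`, awaits measurement. It differs from compound 3 by hydrogen in place of methyl on a saturated chain carbon bound to a carbonyl carbon and two saturated chain carbons, the same kind of change as that from compound 1 to compound 2, but at another place: a saturated chain carbon bound to a carbonyl carbon and two saturated chain carbons, rather than one bound to an oxygen next to a carbonyl group. Within the data shown here, because the only precedent, a number 23 percentage points higher from compound 1 to compound 2 (beyond the scatter), sits at a different place, it is not assumed to carry over, and the expectation for compound 4 is wide, starting from compound 3 at 53%. Compound 4 is expected to give 40%, between 20% and 65%, an estimated step of a number 13 percentage points lower from compound 3 to compound 4 (beyond the scatter).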

Compound 4, percent of the compound remaining: 26%
Estimate against measurement, compound 4: 14 percentage points above; the measured number falls inside the stated range.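

In this assay, going from tert-butyl to isopropyl gave a number 27 percentage points lower from compound 3 to compound 4 (beyond the scatter). Hydrogen in place of methyl therefore did not keep its direction from one core to the other, and the two steps differ: the same change on two cores in this assay, a number 23 percentage points higher (beyond the scatter) from compound 1 to compound 2 and a number 27 percentage points lower (beyond the scatter) from compound 3 to compound 4, 50 percentage points apart, beyond the scatter of two such steps This shows that the earlier step could not be carried over here, but it does not separate core from place, since the change sits on a saturated chain carbon bound to a carbonyl carbon and two saturated chain carbons in one pair and on one bound to an oxygen next to a carbonyl group in the other.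

The compounds shown leave open how this change reads at a single place on both cores. They also leave open how a longer chain or a cyclopropyl group in place of isopropyl would stand in this assay.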